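This account rests on a few compounds, and the source may have more. Where it says the series, first, only, none or still open, it means among the compounds named here.

Measured compounds and their values in an ADME assay on HeLa cells (Homo sapiens) for cytotoxicity, read by sulforhodamine B assay, with a stated time of 48 h, tested at 10 uM; on this read-out higher numbers stand for more inhibition at the one concentration tested (going by the name of the read-out) and lower numbers for less inhibition:

Compound 1, `COc1nc2ccc(Br)cc2cc1C(c1ccccc1)n1cc(C2CC2)nn1`: -5.84%
Compound 2, `COc1nc2ccc(Br)cc2cc1C(c1ccccc1)n1cc(-c2ccccc2F)nn1`: 14.1%
Compound 3, `CCCCc1cn(C(c2ccccc2)c2cc3cc(Br)ccc3nc2OC)nn1`: -2.87%

Compound 3 stands second highest of the three, though its gap to compound 1, a number 3 percentage points higher from compound 1 to compound 3 (within the scatter), is within the scatter; only compound 2 is clearly apart, as the step of a number 17 percentage points lower from compound 2 to compound 3 (beyond the scatter) shows.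

Compound 4, `COc1nc2ccc(Br)cc2cc1C(c1ccccc1)n1cc(-c2ccc(Br)cc2)nn1`, differs from compound 3 in one place: 4-bromophenyl in place of butyl on an aromatic carbon. Among the measured compounds shown here, two measured steps bear on this. A phenyl ring in place of a small alkyl group raised the value, a number 19.9 percentage points higher from compound 1 to compound 2 (beyond the scatter), and the reverse exchange lowered it, a number 17 percentage points lower from compound 2 to compound 3 (beyond the scatter). Putting an aromatic ring back in place of butyl is therefore expected to give a modest rise in this assay, roughly a number 16.9 percentage points higher from compound 3 to compound 4 (beyond the scatter). Compound 4 is thus estimated at 14%, between 0% and 28%.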

Compound 4, a percentage reported as inhibition, at one concentration (the size of the read-out at that concentration, not a potency): 6.92%
The estimate for compound 4 lay 7.1 percentage points above the measured number; measured number inside the range.
By their numbers in this assay, from the lowest: compounds 1, 3, 4 and 2 (each within the scatter of the next, the first and the last beyond it).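

In this assay, an aromatic ring at this position does not by itself set a compound apart: exchanging butyl for 4-bromophenyl gives a number 9.8 percentage points higher from compound 3 to compound 4 (within the scatter), and exchanging 2-fluorophenyl for 4-bromophenyl gives a number 7.2 percentage points lower from compound 2 to compound 4 (within the scatter). Only the exchange of cyclopropyl for 4-bromophenyl gives a clear difference, a number 12.8 percentage points higher from compound 1 to compound 4 (beyond the scatter). Nothing available explains these numbers. The compounds shown leave open how a phenyl ring carrying an amine or a carboxylic acid would read here. They also leave open whether a chain longer than butyl on this aromatic carbon would differ from butyl.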